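Swapping the amine on a shared core with no measured step

This account rests on a few compounds, and the source may have more. Where it says the series, first, only, none or still open, it means among the compounds named here.

Measured compounds:
- compound 1, `Cc1nc(N2CCN(S(C)(=O)=O)CC2)nc2ccc(NC(=O)COc3ccc(Cl)cc3)cc12`: > 10000 nM
- compound 2, `Cc1nc(N2CCC(O)CC2)nc2ccc(NC(=O)C(C)(C)Oc3ccc(Cl)cc3)cc12`: > 10000 nM

In a functional assay on CHO-K1 cells for antagonist activity at melanin-concentrating hormone receptor 1 (Homo sapiens), read by inositol phosphate accumulation (a lower number here means a stronger inhibitor, a higher number a weaker inhibitor), compound 1 gives > 10000 nM, which is a limit of the assay and not a number. Compound 2 likewise gives > 10000 nM in this assay, again a limit. Compound 1 therefore stands at the limit of > 10000 nM in this assay, at which 2 of the 2 values shown sit, so neither value sets a real mark for compound 1 to be compared against.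

Compound 3, `Cc1nc(N2CCC(O)CC2)nc2ccc(NC(=O)COc3ccc(Cl)cc3)cc12`, is still to be measured in this assay. It differs from compound 1 in one place: 4-hydroxypiperidin-1-yl in place of 4-(methylsulfonyl)piperazin-1-yl on an aromatic carbon. In words, 4-hydroxypiperidin-1-yl stands in place of 4-(methylsulfonyl)piperazin-1-yl on an aromatic carbon of the shared core. Going by the values given here, no step between measured compounds shows what such a swap does here, and compound 2, which already carries the 4-hydroxypiperidin-1-yl group, also sits at the limit. The expectation is that compound 3 shows no step beyond the scatter, so that the step from compound 1 to compound 3 is estimated as a number no higher from compound 1 to compound 3 (the limit leaves the size open). Compound 3 is estimated at 10000 nM in this assay, in a range from 3000 nM to 30000 nM, with a high chance that only a limit is reported.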

Compound 3, half-maximal inhibitory concentration: 163 nM
The estimate for compound 3 lay 61-fold (1.79 log units) above the measured number; the measured number lies below the stated range.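

In this assay, the position between two ring nitrogen atoms on the shared core proves sensitive to the ring amine it carries, with an at least 61-fold lower number from compound 1 to compound 3 (1.78 log units; beyond the scatter) when 4-hydroxypiperidin-1-yl stands in place of 4-(methylsulfonyl)piperazin-1-yl. Compound 3 is the first compound here with a real number, and the full size of the step stays open because compound 1 sits at a limit of the assay: the limit of > 10000 nM in this assay, at which 2 of the 3 values shown sit.

Compound 2 carries the same 4-hydroxypiperidin-1-yl group on a different amide side chain, and its > 10000 nM is a limit of the assay, so this amine does not give a measurable number with every side chain.

The compounds shown cannot tell whether the hydroxyl group matters in itself or whether the difference lies in losing the methylsulfonyl group, since the swap changes the whole ring substituent at once. A plain piperidin-1-yl or a 4-methoxypiperidin-1-yl group at this position, on the side chain of compound 3, would help to separate these two readings.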